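The compounds below may be only part of what the source reports. "The series", "measured", "known", "first", "only" and "open" are said of these compounds alone.

Measured so far:
compound 1 `Cc1ccc(C(=O)c2ccn(-c3ccc4c(c3)B(O)OC4)c2)cc1`: > 10 ug/mL
compound 2 `COc1cc(C(=O)c2ccn(-c3ccc4c(c3)B(O)OC4)c2)cc(OC)c1OC`: 1.15 ug/mL

In an ADME assay on L929 cells (Mus musculus) for cytotoxicity, read by resazurin assay, with a stated time of 72 h (a lower number here means a stronger inhibitor, a higher number a weaker inhibitor), compound 1 gives > 10 ug/mL, and this is a limit of the assay rather than a number. Compound 1 therefore stands at the limit of > 10 ug/mL in this assay, at which 1 of the 2 values shown sits. Among the compounds with values here, compound 2 gives 1.15 ug/mL in this assay; no single-point step joins compound 2 to compound 1, so the two values simply stand side by side. Compound 3 `NCCCC(=O)c1ccn(-c2ccc3c(c2)B(O)OC3)c1` has not yet been measured in this assay. It differs from compound 1 in one place: 3-aminopropyl in place of 4-methylphenyl on a carbonyl carbon. Within the data shown here, with no measured step of this kind to lean on, and with compound 1 sitting at a limit, the change is expected to make no difference beyond the scatter, and a limit may well be reported again. Compound 3 is thus estimated at 15 ug/mL, in a range from 4 ug/mL to 50 ug/mL, which means an expected step that the limit leaves unreadable from compound 1 to compound 3.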

Compound 3, half-maximal inhibitory concentration: > 10 ug/mL
Compound 3 was reported as a limit; the forecaster's own chance of this, stated with the estimate: 60%; the middle value is on the limit's open side.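

Compound 1 and compound 3 are both reported only as limits in this assay, so no step between them can be read: the limit of > 10 ug/mL in this assay, at which 2 of the 3 values shown sit.

Still open, from the compounds shown here alone, is whether 3-aminopropyl in place of 4-methylphenyl on a carbonyl carbon changes the true value at all.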